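A few compounds are considered here, and "the series" means these few. Any claim that something is new, unique, unknown or untested is made for them only; others in the source may bear on it.

Compound 1 `COC(=O)c1c(Nc2ccc(C)cc2)sc(C(=O)c2ccc(OC)cc2)c1C`: "not active" (no number reported)
Compound 2 `COc1ccc(C(=O)c2sc(Nc3ccccc3)c(C(=O)O)c2C)cc1`: 19.6%
Compound 3 `COc1ccc(C(=O)c2sc(Nc3ccc(C)cc3)c(C(=O)O)c2C)cc1`: "not active" (no number reported)

The three measured compounds share one core and were all tested in a functional assay, with a stated time of 150 min, tested at 5 ug/mL; on this read-out lower numbers stand for a weaker effect and higher numbers for a stronger effect at the one concentration tested. Within the data shown here, compound 2 is the only one with a reported number, giving 19.6%. Among the measured compounds shown here, compound 1 was reported as "not active" (no number reported), and compound 3 likewise as "not active" (no number reported), so compound 3 stands among the two entries with no number, and no step between measured compounds could be computed.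

Compound 4 `Cc1ccc(Nc2sc(C(=O)c3ccc(C)cc3)c(C)c2C(=O)O)cc1` differs from compound 3 in one place: methyl in place of methoxy on an aromatic carbon. For the measured compounds named here, since compound 3 carries no number, no step can be stated for the change to compound 4 in this assay; the account rests on compound 3 being reported as "not active" (no number reported). The change of methyl in place of methoxy on an aromatic carbon is expected to move the read-out by no more than the scatter, if at all. Compound 4 is therefore expected to give an activity of about 5% in this assay, within a range of 0% to 20%, with a fair chance that, like compound 3, it is simply reported as not active.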

Compound 4, a percentage reported as activity, at one concentration (the size of the read-out at that concentration, not a potency): "not active" (no number reported)
For compound 4 the study gives words and no number, so the estimate cannot be set against anything.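

In this assay compound 3 is reported as "not active" (no number reported) and compound 4 as "not active" (no number reported) so no step can be read between them. The compounds shown leave open whether changing 4-methoxyphenyl to 4-methylphenyl alters the read-out at all. No evidence here bears on this result.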